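Piperidin-1-yl in place of pyrrolidin-1-yl: what to expect

The source may report more compounds than this note shows. Statements on the series, on what has been measured and on what is new or still open speak of the compounds shown alone.

Compound 1 `COc1ccccc1/C=C/C(=O)c1sc(N2CCCC2)nc1N`: > 50 ug/mL, a limit
Compound 2 `Nc1nc(N2CCCC2)sc1C(=O)/C=C/c1ccc(Br)cc1`: 41.3 ug/mL
Compound 3 `Nc1nc(N2CCCC2)sc1C(=O)/C=C/c1ccc(Cl)cc1Cl`: 12.6 ug/mL

All three compounds were tested in a functional assay on MCF7 cells (Homo sapiens) for antiproliferative activity, read by MTT assay, with a stated time of 48 h; on this read-out lower numbers stand for stronger inhibition and higher numbers for weaker inhibition. The result for compound 1, > 50 ug/mL, is a limit of the assay and not a number. That leaves two real numbers to compare. Compound 3 has the lower of them at 12.6 ug/mL, and compound 2 sits at 41.3 ug/mL, a gap beyond the usual scatter of repeated measurements.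

The next compound to be tested is compound 4 `Nc1nc(N2CCCCC2)sc1C(=O)/C=C/c1ccc(Cl)cc1Cl`. It matches compound 3 except for one group, piperidin-1-yl in place of pyrrolidin-1-yl on an aromatic carbon. All three measured compounds carry pyrrolidin-1-yl, so none of them shows what this exchange does. The best available guide is the closest measured relative, compound 3 at 12.6 ug/mL. Among the compounds with values here, with no measured precedent, no step beyond the scatter is expected in this assay. The expected change is small: a 1.0-fold higher number from compound 3 to compound 4 (0.01 log units; within the scatter). For compound 4 the estimated value is 13 ug/mL, with an expected range from 5 ug/mL to 38 ug/mL.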

Compound 4, half-maximal inhibitory concentration: 25.5 ug/mL
The estimate for compound 4 lay 2.0-fold (0.29 log units) below the measured number; low and high end bracket the measured number.
By their numbers in this assay, from the lowest: compound 3; then compounds 4 and 2 (each within the scatter of the next). At a limit, above all of these: compound 1.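

Until now every measured compound carried pyrrolidin-1-yl, so the carbon of the five-membered aromatic ring that bears this group had given no reading of its own. In this assay the exchange for piperidin-1-yl, a six-membered non-aromatic ring in place of a five-membered one, gives a 2.0-fold higher number from compound 3 to compound 4 (0.31 log units; beyond the scatter) and this modest step lies beyond the scatter, which shows that the number does respond to the ring at this position, with the five-membered ring giving the lower number in this pair. Nothing measured in this set explains why this exchange raises the number.

On these data alone, this is a single pair, so it is still open whether the same step would appear with the bromine-bearing aromatic ring of compound 2 or with the methoxy-bearing aromatic ring of compound 1. Also open, as far as these compounds go, is how this position would respond to a ring with a second hetero atom, such as morpholin-4-yl, or to an open-chain amine, such as diethylamino, and whether either would give a lower number than the two rings compared here.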